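Swapping furan for pyridine on an amide carbonyl

The source may hold more compounds than are shown below. What is called first, only, known or untested is meant among the compounds shown, and "the series" means these compounds.

Compound 1, `Cc1nc(NC(=O)c2ccccc2)c2nn(-c3ccccc3)cc2n1`, gives 30% in an assay on CHO cells for displacement of a labelled ligand from adenosine receptor A1 (Homo sapiens), read by scintillation counting, with a stated time of 120 min, tested at 1 uM; a lower number here means less inhibition, a higher number more inhibition at the concentration tested (going by the name of the read-out).
Compound 2, `CC(=O)Nc1nc(C)nc2cn(-c3ccccc3)nc12`, gives 25% in this assay.
Compound 3, `Cc1nc(NC(=O)c2ccco2)c2nn(-c3ccccc3)cc2n1`, gives 20% in this assay.

All three compounds share one core and differ only in the group attached to the carbonyl carbon of the amide. The number for compound 3 sits at the bottom of the three, but its distance to compound 2 and to compound 1 both lie within the scatter, so the three cannot be told apart on these numbers. The measured steps say the same: a number 5 percentage points lower from compound 1 to compound 2 (within the scatter), a number 10 percentage points lower from compound 1 to compound 3 (within the scatter) and a number 5 percentage points lower from compound 2 to compound 3 (within the scatter) are all within the scatter.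

Compound 4, `Cc1nc(NC(=O)c2cccnc2)c2nn(-c3ccccc3)cc2n1`, is the next variation at the same place: pyridin-3-yl in place of furan-2-yl on a carbonyl carbon.

The three measured steps all bear on this change, since each one exchanges the group on the carbonyl carbon, and none of them moved the number beyond the scatter. The step to compound 4 is therefore expected to be of the same kind: a number 3 percentage points higher from compound 3 to compound 4 (within the scatter), which is no real change. On that basis compound 4 is estimated to give 23% in this assay, with a range from 8% to 40%.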

Compound 4, a percentage reported as inhibition, at one concentration (the size of the read-out at that concentration, not a potency): 12%
Estimate against measurement, compound 4: 11 percentage points above; low and high end bracket the measured number.
By their numbers in this assay, from the lowest: compounds 4, 3, 2 and 1 (each within the scatter of the next, the first and the last beyond it).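

Pyridin-3-yl brings the first steps at this carbonyl carbon that lie beyond the scatter in this assay (a number 13 percentage points lower from compound 2 to compound 4 (beyond the scatter); a number 18 percentage points lower from compound 1 to compound 4 (beyond the scatter)), so the group in this place can shift the inhibition read at the tested concentration, though the shifts shown are modest. The exchange of furan-2-yl for pyridin-3-yl on its own does not show this (a number 8 percentage points lower from compound 3 to compound 4 (within the scatter)), and only the comparisons of pyridin-3-yl with methyl and with phenyl separate from the scatter, while furan-2-yl separates from neither of those two. Nothing measured alongside these numbers accounts for the difference between the groups.

From the compounds shown here alone, it remains open what an amine, a carboxylic acid or a longer alkyl chain on the same carbonyl carbon would do to the number, and whether a pyridin-4-yl group would read like pyridin-3-yl. Going by these compounds, each number is also a reading at a single concentration, so how these modest differences would translate into potency stays unknown.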